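A few compounds are considered here, and "the series" means these few. Any claim that something is new, unique, unknown or untested is made for them only; others in the source may bear on it.

Measured so far:
- Compound 1 `CC1[C@@H](c2cccc([N+](=O)[O-])c2)O[C@@H](c2cccc([N+](=O)[O-])c2)O[C@@]12C=CC(=O)O2`: > 20000 nM
- Compound 2 `O=C1C=C[C@]2(C[C@@H](c3ccccc3)O[C@@H](c3cccc([N+](=O)[O-])c3)O2)O1`: 340 nM

Both results come from a functional assay on MJ cells (Homo sapiens) for antiproliferative activity, with a stated time of 48 h; on this read-out higher numbers stand for weaker inhibition and lower numbers for stronger inhibition. The result for compound 1 is a limit. Among the compounds with values here, compound 2 therefore holds the only actual number so far, and it serves as the reference point for the next comparison.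

Compound 3 `O=C1C=C[C@]2(C[C@@H](c3cccc([N+](=O)[O-])c3)O[C@@H](c3cccc([N+](=O)[O-])c3)O2)O1` is compound 2 with its phenyl changed to 3-nitrophenyl, a nitro in place of hydrogen on an aromatic carbon. Within the data shown here, no step between measured compounds covers this change, so the expectation is loose. A moderate shift toward weaker inhibition is expected, although a result within the scatter of compound 2 would not be surprising. The expected change is a 1.8-fold higher number from compound 2 to compound 3 (0.25 log units; within the scatter). The estimated value for compound 3 is 600 nM, with an expected range from 120 nM to 3000 nM.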

Compound 3, half-maximal inhibitory concentration: 170 nM
Beside the measured number, compound 3's estimate is 3.5-fold (0.55 log units) above it, and the stated range covers the measured number.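

In this assay, a nitro on an aromatic carbon, meta to a large group, is accommodated without a step that can be told from the scatter: a 2.0-fold lower number from compound 2 to compound 3 (0.30 log units; within the scatter). The saturated ring carbon is far more sensitive, since hydrogen in place of methyl there gives an at least 110-fold lower number from compound 1 to compound 3 (2.07 log units; beyond the scatter), so the series now shows that this methyl matters much more than the phenyl to 3-nitrophenyl change. The value for compound 1 is a limit and not a number: the limit of > 20000 nM in this assay, at which 1 of the 3 values shown sits.

On these data alone, whether the same aromatic position accepts a different group, such as an amine or a carboxylic acid, remains open. Also open, as far as these compounds go, is whether an ethyl or a longer chain on the saturated ring carbon behaves as methyl does, and whether methyl there has the same effect with a plain phenyl, as in compound 2.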